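Replacing Methoxy with Methylpiperazinyl on a Shared Core

The source may report more compounds than this note shows. Statements on the series, on what has been measured and on what is new or still open speak of the compounds shown alone.

Compound 1 `Nc1c2c(=O)[nH]c(-c3ccccc3)cc2nn1-c1ccccc1`: 23%
Compound 2 `COc1ccc(-c2cc3nn(-c4ccccc4)c(N)c3c(=O)[nH]2)cc1`: 28%

In an assay on isolated protein for inhibition of serine/threonine-protein kinase D2 (Homo sapiens), read by mobility shift assay, tested at 30 uM (on this read-out lower numbers stand for less inhibition and higher numbers for more inhibition at the one concentration tested (going by the name of the read-out)), compound 1 gives 23%, and compound 2 gives 28%. Compound 2 stands level with compound 1, since a number 5 percentage points higher from compound 1 to compound 2 (within the scatter) lies within the scatter. Compound 3 `CN1CCN(c2ccc(-c3cc4nn(-c5ccccc5)c(N)c4c(=O)[nH]3)cc2)CC1` differs from compound 2 in one place: 4-methylpiperazin-1-yl in place of methoxy on an aromatic carbon. For the measured compounds named here, the only step available touches the same aromatic carbon, where methoxy replaced hydrogen, and it moved the read-out by a number 5 percentage points higher from compound 1 to compound 2 (within the scatter), within the scatter. With so small a precedent, no step beyond the scatter is expected, a number 2 percentage points higher from compound 2 to compound 3 (within the scatter). Compound 3 is therefore estimated at 30%, between 12% and 52%.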

Compound 3, a percentage reported as inhibition, at one concentration (the size of the read-out at that concentration, not a potency): 15%
For compound 3 the middle estimate is 15 percentage points above the measured one, and the stated range covers the measured number.
By their numbers in this assay, from the lowest: compounds 3, 1 and 2 (each within the scatter of the next, the first and the last beyond it).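

For the compounds shown here, at this aromatic carbon, the change from methoxy to 4-methylpiperazin-1-yl gives the first step beyond the scatter in this assay (a number 13 percentage points lower from compound 2 to compound 3 (beyond the scatter)), so the position does respond to what sits on it. Measured against plain hydrogen, the same group stays within the scatter (a number 8 percentage points lower from compound 1 to compound 3 (within the scatter)), which separates it from methoxy but not from hydrogen. Nothing available explains this step. Going by these compounds, whether the step belongs to the piperazine ring or to its methyl group remains open. Also open, on these data alone, is how a morpholin-4-yl or dimethylamino group would read at this same carbon.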